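The source may hold more compounds than are shown below. What is called first, only, known or untested is meant among the compounds shown, and "the series" means these compounds.

Compound 1, `Cc1cc2nc(-c3cccc(Oc4ccccc4)c3)cc(-c3ccccc3)c2cc1C`: 3410 nM
Compound 2, `N#Cc1ccc2nc(-c3cccc(Oc4ccccc4)c3)cc(-c3ccccc3)c2c1`: 822 nM

In a functional assay on MCF7 cells (Homo sapiens) for inhibition, read by MTT assay, with a stated time of 24 h (a lower number here means a stronger inhibitor, a higher number a weaker inhibitor), compound 2 gives 822 nM and compound 1 gives 3410 nM. Of the two numbers measured, compound 2 stands lowest, and its gap to compound 1 lies beyond the usual scatter of repeated measurements.

Compound 3, `Clc1ccc2nc(-c3cccc(Oc4ccccc4)c3)cc(-c3ccccc3)c2c1`, has not been measured. It differs from compound 2 in one place: chloro in place of cyano on an aromatic carbon. Among the compounds with values here, no measured pair shows this change, so its effect is unknown.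

Compound 3 is expected to stay close to compound 2, with a step of a 1.6-fold higher number from compound 2 to compound 3 (0.20 log units; within the scatter), in this assay toward a slightly higher number but not clearly beyond the scatter. The estimated value of compound 3 is 1300 nM, in a range from 500 nM to 3500 nM.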

Compound 3, half-maximal inhibitory concentration: 11000 nM
Compound 3: the middle estimate sits 8.5-fold (0.93 log units) below what was measured; measured number outside the range, above it.
By their numbers in this assay, from the lowest: compound 2; then compound 1; then compound 3.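

Chloro in place of cyano on this aromatic carbon gives a 13-fold higher number from compound 2 to compound 3 (1.13 log units; beyond the scatter) in this assay and is a large change. Within the data shown here, this is the first single-place comparison, and it shows that this position is sensitive to its substituent, with cyano and chloro not interchangeable there. Nothing shown explains why the step is so large.

Among these compounds, with only this pair, it remains open how other groups on this carbon would compare. An amine, a carboxylic acid or a methoxy group could fall anywhere relative to cyano and chloro.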